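The source may hold more compounds than are shown below. What is called first, only, known or untested is meant among the compounds shown, and "the series" means these compounds.

Measured so far:
compound 1 `OC(c1ccccc1)c1c(C(F)(F)F)nc2ccc(Br)cc2c1Br`: 1510 nM
compound 2 `COc1ccccc1NC(=S)Nc1ccc2nc(Oc3ccc(F)cc3C(C)O)c(Cc3ccccc3)cc2c1`: 16000 nM
compound 3 `CC(c1cc(F)ccc1Oc1nc2ccc(-n3cc(-c4ccccc4)nn3)cc2cc1Cc1ccccc1)n1ccnc1`: 64000 nM

In an ADME assay on MRC5 cells (Homo sapiens) for cytotoxicity, read by resazurin assay, with a stated time of 7 days (a higher number here means that more compound is tolerated, a lower number that less compound is tolerated), compound 2 gives 16000 nM and stands second highest of the three, under compound 3 and over compound 1, with both gaps beyond the scatter. Compound 4 `COc1cccc(NC(=S)Nc2ccc3nc(Oc4ccc(F)cc4C(C)O)c(Cc4ccccc4)cc3c2)c1` has 3-methoxyphenyl in place of 2-methoxyphenyl on an amide-type nitrogen as its difference from compound 2: 3-methoxyphenyl in place of 2-methoxyphenyl on an amide-type nitrogen. The two have the same atoms, joined differently. Within the data shown here, no measured pair shows a change of this kind, so the expectation rests on compound 2 alone. A step of no change at the digits printed from compound 2 to compound 4 (within the scatter) is expected to stay within the scatter, with no direction favoured. Compound 4 is estimated at 16000 nM with 6000 nM to 40000 nM as the expected range.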

Compound 4, half-maximal cytotoxic concentration in the MRC5 assay: 64000 nM
Estimate against measurement, compound 4: 4.0-fold (0.60 log units) below; the measured number lies above the stated range.
By their numbers in the MRC5 assay, from the lowest: compound 1; then compound 2; then compounds 3 and 4 (each within the scatter of the next).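

In the MRC5 assay compound 2 gives 16000 nM and compound 4 gives 64000 nM; 3-methoxyphenyl in place of 2-methoxyphenyl on an amide-type nitrogen gives a 4.0-fold higher number from compound 2 to compound 4 (0.60 log units; beyond the scatter), showing that at this position the same atoms, joined differently, are enough to separate two compounds. In a physicochemical assay for lipophilicity (on this read-out lower numbers stand for lower lipophilicity and higher numbers for higher lipophilicity), compound 2 gives 7.86 and compound 4 gives 7.86, and the same exchange gives no change at the digits printed from compound 2 to compound 4 (within the scatter), so that read-out does not distinguish the pair. Nothing available bears on why the two compounds part in cell tolerance. From the compounds shown here alone, whether the step is particular to these two methoxyphenyl groups remains open, as does what a plain phenyl or a pyridine ring would give at this place.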